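Amide Amine Variation on a Sulfonyl Piperazine Core

The source may report more compounds than this note shows. Statements on the series, on what has been measured and on what is new or still open speak of the compounds shown alone.

Compound 1 `CC(C(=O)N1CCCCC1)N1CCN(S(=O)(=O)c2ccc(C(C)(C)C)cc2)CC1`: > 40000 nM (a limit)
Compound 2 `CC(C(=O)N1CCC2(CC1)CC2)N1CCN(S(=O)(=O)c2ccc(C(C)(C)C)cc2)CC1`: > 40000 nM (a limit)
Compound 3 `CC(C(=O)N1CCCc2ccccc21)N1CCN(S(=O)(=O)c2ccc(C(C)(C)C)cc2)CC1`: > 40000 nM (a limit)

In an ADME assay on HepG2 cells (Homo sapiens) for inhibition, with a stated time of 48 h (on this read-out higher numbers stand for an effect only at larger amounts of compound and lower numbers for an effect already at smaller amounts), compound 1 gives > 40000 nM, which is a limit of the assay and not a number. Compound 2 in this assay gives > 40000 nM, again only a limit. Compound 3 in this assay gives > 40000 nM, once more a limit. Because of the limit of > 40000 nM in this assay, at which 3 of the 3 values shown sit, none of the three values can be placed on a scale, and the steps between them stay unreadable: a step that the two limits leave unreadable from compound 1 to compound 2, a step that the two limits leave unreadable from compound 1 to compound 3 and a step that the two limits leave unreadable from compound 2 to compound 3. Compound 1 therefore stands at the limit, with nothing to rank it against the others.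

Compound 4 `CC(C(=O)N1CCc2ccccc2C1C)N1CCN(S(=O)(=O)c2ccc(C(C)(C)C)cc2)CC1` differs from compound 1 in one place: 1-methyl-1,2,3,4-tetrahydroisoquinolin-2-yl in place of piperidin-1-yl on a carbonyl carbon. The three measured steps all concern the same position on the carbonyl carbon, and all three left the read-out at the limit. Since every variation of the amine on this carbonyl carbon so far gave only a limit, compound 4 is expected to behave alike, with no readable step, a step that the limit leaves unreadable from compound 1 to compound 4. Compound 4 is thus estimated at 60000 nM in this assay, within a range from 30000 nM to 150000 nM, most likely reported again as a limit.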

Compound 4, half-maximal effective concentration: 28000 nM
The estimate for compound 4 lay 2.1-fold (0.33 log units) above the measured number; the whole stated range lies above it.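

In this assay compound 4 is the only compound shown that gives a number rather than a limit, so the group on this carbonyl carbon can bring the read-out into a readable range, with an at least 1.4-fold lower number from compound 1 to compound 4 (0.15 log units; that floor lies within the scatter) and an at least 1.4-fold lower number from compound 3 to compound 4 (0.15 log units; that floor lies within the scatter) and also an at least 1.4-fold lower number from compound 2 to compound 4 (0.15 log units; that floor lies within the scatter) as the steps to it. Compound 3, whose group likewise holds a six-membered aromatic ring, gives > 40000 nM and that is a limit of the assay, so such a ring alone does not produce a number here. On these data alone, the real size of all three steps stays unknown, and each is only a floor, because the other values are limits: the limit of > 40000 nM in this assay, at which 3 of the 4 values shown sit.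

The compounds shown leave open whether the plain 1,2,3,4-tetrahydroisoquinolin-2-yl group, without its methyl, would also give a number, and so what the methyl contributes. They also leave open how a morpholin-4-yl group on the carbonyl carbon, or a carboxylic acid on the aromatic ring of compound 4, would shift the read-out in this assay and whether any such change would move it clear of the usual scatter.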